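The compounds below may be only part of what the source reports. "The series", "measured", "known", "first", "only" and "open" are said of these compounds alone.

Working notes on the series. Compound 1 `O=C1CSC(c2ccccc2)N1n1c(CSc2nnc(-c3ccncc3)o2)nc2ccccc2c1=O` is the parent; in a functional assay on the whole organism (strain Charles-Foster albino) for inhibition, with Rattus norvegicus as the target, read by paw edema, at a dose of 50 mg/kg by the oral route (on this read-out lower numbers stand for less inhibition and higher numbers for more inhibition at the one dose given (going by the name of the read-out)), compound 1 gives 30.1%. Compound 2 `O=C1CSC(c2ccccc2)N1n1c(CSc2nnc(-c3ccncc3)o2)nc2ccc(Br)cc2c1=O` carries bromo on the shared core, and in this assay compound 2 gives 31.3%. The step of a number 1.2 percentage points lower from compound 2 to compound 1 (within the scatter) comes from hydrogen in place of bromo on an aromatic carbon. Compound 3 `O=C1CSC(c2ccc(O)cc2)N1n1c(CSc2nnc(-c3ccncc3)o2)nc2ccc(Br)cc2c1=O` keeps that bromo and adds the change phenyl to 4-hydroxyphenyl; in this assay compound 3 gives 32.7%, the step from compound 2 being a number 1.4 percentage points higher from compound 2 to compound 3 (within the scatter). All three numbers sit within the scatter of one another, so no order among them is claimed.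

Compound 4 `O=C1CSC(c2ccc(O)cc2)N1n1c(CSc2nnc(-c3ccncc3)o2)nc2ccccc2c1=O` awaits measurement in this assay. It differs from compound 3 by hydrogen in place of bromo on an aromatic carbon. Among the compounds with values here, this is the same change as the one from compound 2 to compound 1, made twice, with the place described in identical words both times; the two cores on which it is made differ by hydroxy in place of hydrogen on an aromatic carbon. Within the data shown here, the one measured instance, a number 1.2 percentage points lower from compound 2 to compound 1 (within the scatter), stayed within the scatter, so a step of like size is expected here. The expected step is a number 1.2 percentage points lower from compound 3 to compound 4 (within the scatter), resting on compound 3 giving 32.7% and on compound 2 to compound 1 showing a number 1.2 percentage points lower from compound 2 to compound 1 (within the scatter). Compound 4 is expected to give 31.5%, estimated to lie between 23% and 40%.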

Compound 4, a percentage reported as inhibition, in the whole organism at one dose (the size of the read-out at that dose, not a potency): 31.7%
Compound 4: the middle estimate sits 0.2 percentage points below what was measured, within the range that was stated.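

In this assay, hydrogen in place of bromo on an aromatic carbon gives a number 1 percentage points lower from compound 3 to compound 4 (within the scatter), and this matches the earlier step on the other core: the same change on two cores in this assay, a number 1.2 percentage points lower (within the scatter) from compound 2 to compound 1 and a number 1 percentage points lower (within the scatter) from compound 3 to compound 4, 0.2 percentage points apart, within the scatter of two such steps. Hydroxy in place of hydrogen on an aromatic carbon gives a number 1.6 percentage points higher from compound 1 to compound 4 (within the scatter), and this too matches its earlier step: the same change on two cores in this assay, a number 1.4 percentage points higher (within the scatter) from compound 2 to compound 3 and a number 1.6 percentage points higher (within the scatter) from compound 1 to compound 4, 0.2 percentage points apart, within the scatter of two such steps. Within the data shown here, the two changes therefore carry from one core to the other without a visible difference, but all four steps lie within the scatter, so this shows only that neither change gave a step beyond the scatter on either core, not that a step of real size would carry over in the same way.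

The compounds shown set only bromo and hydroxy against hydrogen, so it stays open whether an amine, a carboxylic acid or a methoxy group at these places would give a step beyond the scatter. As far as these compounds go, it also stays open whether such a step would keep its size from one core to the other, and how the series reads at any other dose.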